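Replacing the sulfonamide chain of compound 1 with an amide

This account rests on a few compounds, and the source may have more. Where it says the series, first, only, none or still open, it means among the compounds named here.

Of the compounds shown here, three have been measured in a functional assay on H4 cells for agonist activity at growth hormone secretagogue receptor type 1 (Homo sapiens), read by FLIPR; on this read-out higher numbers stand for an effect only at larger amounts of compound and lower numbers for an effect already at smaller amounts. Compound 1 `CC(C)(N)C(=O)N[C@H](COCc1ccccc1)c1nnnn1CCCCCNS(C)(=O)=O` gives 75 nM, compound 2 `CC(C)(N)C(=O)N[C@H](COCc1ccccc1)c1nnn(CCCc2ccccc2NS(C)(=O)=O)n1` gives 107 nM, and compound 3 `COC(=O)C(c1ccccc1)n1nnc([C@@H](COCc2ccccc2)NC(=O)C(C)(C)N)n1` gives 3170 nM. Compound 1 carries the lowest number of the three; compound 2 lies within the scatter of it, while compound 3 sits far beyond the scatter in the direction of an effect only at larger amounts. Compound 1 and compound 2 both carry a methanesulfonamide on a chain attached to the shared core; compound 3 has neither that chain nor that group.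

Compound 4 `CC(C)(N)C(=O)N[C@H](COCc1ccccc1)c1nnnn1CCC(=O)NCCCc1ccccc1` is not yet measured. It differs from compound 1 by (3-phenylpropyl)carbamoyl in place of 3-(methanesulfonamido)propyl on a saturated chain carbon, two bonds along the chain from an aromatic nitrogen. Among the measured compounds shown here, no measured pair shows this change, so the expectation rests on comparison only. Compound 2 keeps a phenyl on its chain and gives 107 nM; compound 1 gives 75 nM. Compound 3, with a phenyl and an ester directly on the chain and no sulfonamide, gives 3170 nM. Compound 4 gives up the sulfonamide but keeps a hydrogen-bond donor in the carbamoyl and adds a phenyl on a propyl chain. A modest move toward weaker activity is expected, a 2.7-fold higher number from compound 1 to compound 4 (0.43 log units; beyond the scatter), beyond the scatter yet well short of the gap to compound 3. Compound 4 is expected to give 200 nM, in the range 60 nM to 700 nM.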

Compound 4, half-maximal effective concentration: 59 nM
For compound 4 the middle estimate is 3.4-fold (0.53 log units) above the measured one, and the stated range ends above it.
By their numbers in this assay, from the lowest: compounds 4, 1 and 2 (each within the scatter of the next); then compound 3.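

In this assay, among the compounds shown here, (3-phenylpropyl)carbamoyl in place of 3-(methanesulfonamido)propyl on a saturated chain carbon, two bonds along the chain from an aromatic nitrogen, gives a 1.3-fold lower number from compound 1 to compound 4 (0.10 log units; within the scatter) and is the first one-place comparison. At this position, then, the methanesulfonamide is not needed for a number within the scatter of compound 1, and the position also accepts a group with more heavy atoms that carries a six-membered aromatic ring of carbon only. Nothing measured beyond these numbers bears on why the two groups read alike.

From the compounds shown here alone, the carbamoyl and the phenyl enter together in compound 4, so their separate contributions remain open, as does the part played by the hydrogen-bond donor present in both the leaving and the entering group. Also open, going by these compounds, is how a carboxylic acid or an amine in place of the phenyl of compound 4 would read on this position, and whether a longer chain would keep the number within the scatter of compound 4.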